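A few compounds are considered here, and "the series" means these few. Any claim that something is new, unique, unknown or untested is made for them only; others in the source may bear on it.

Compound 2 `CCCCCCNc1cnc(C(=O)NCc2ccccc2)cn1` was tested in an ADME assay on HEL cells (Homo sapiens) for cytotoxicity, read by microscopy, with a stated time of 6 days; a higher number here means that more compound is tolerated, a lower number that less compound is tolerated. In this assay compound 2 gives > 100000 nM, which is a limit of the assay and not a number. Compound 1 `CCCCCCCNc1cnc(C(=O)NCc2ccccc2)cn1` likewise gives > 100000 nM in this assay, again a limit. The step that the two limits leave unreadable from compound 1 to compound 2 therefore cannot be read, since (the limit of > 100000 nM in this assay, at which 2 of the 2 values shown sit). Compound 3 `CCCCNc1cnc(C(=O)NCc2ccccc2)cn1` differs from compound 2 by hydrogen in place of ethyl on a saturated chain carbon, four bonds along the chain from a nitrogen on an aromatic ring. Within the data shown here, no measured step gives a size for a change of this kind, so no shift beyond the scatter is expected in this assay. Compound 3 is expected to give about 100000 nM, between 50000 nM and 200000 nM, most likely again as a limit. The expected step of a number no higher from compound 2 to compound 3 (the limit leaves the size open) is accordingly none.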

Compound 3, minimum cytotoxic concentration: > 100000 nM
Compound 3 was reported as a limit (the forecaster's own chance of this, stated with the estimate: 90%); the middle value lies on the limit itself.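

No step among compound 1, compound 2 and compound 3 can be read in this assay, since all three sit at a limit of the assay: the limit of > 100000 nM in this assay, at which 3 of the 3 values shown sit.

The compounds shown leave open at what concentration each would harm these cells, and whether the chain length affects that.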